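From Chloro to Fluoro: Estimating Compound 4

This account rests on a few compounds, and the source may have more. Where it says the series, first, only, none or still open, it means among the compounds named here.

Measured compounds:
Compound 1 `COc1ccc(-c2noc(-c3ccccc3)n2)cc1OC1CCCC1`: > 1000000 nM
Compound 2 `COc1ccc(-c2noc(-c3ccc(F)cc3)n2)cc1O`: > 1000000 nM
Compound 3 `COc1ccc(-c2noc(-c3ccc(Cl)cc3)n2)cc1OC1CCCC1`: 174000 nM

All three were tested in a functional assay on MCF7 cells (Homo sapiens) for antiproliferative activity, read by MTT assay, with a stated time of 24 h; a higher number here means a weaker inhibitor, a lower number a stronger inhibitor. For compound 1 the reported value is a limit of this assay, not a number. The same is true of compound 2. Going by the values given here, compound 3 is therefore the only compound with an actual number, and it stands alone on the scale, while the other two rest at the limit of > 1000000 nM in this assay, at which 2 of the 3 values shown sit.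

Only one measured step connects two of these compounds: an at least 5.7-fold lower number from compound 1 to compound 3 (0.75 log units; beyond the scatter). It shows that placing chloro where hydrogen had been moved a compound from the limit to a measurable number.

Compound 4 `COc1ccc(-c2noc(-c3ccc(F)cc3)n2)cc1OC1CCCC1` is the next compound to be measured. It differs from compound 3 by fluoro in place of chloro on an aromatic carbon. Among the compounds with values here, the step that bears on this change is the one from compound 1 to compound 3, which only tells how chloro compares with hydrogen, not how fluoro compares with chloro. Compound 2, which also carries fluoro, sits at the limit, but it differs from compound 4 elsewhere as well. The expectation is that compound 4 drifts back toward weaker inhibition, a step of a 2.6-fold higher number from compound 3 to compound 4 (0.41 log units; beyond the scatter), so compound 4 is estimated at 450000 nM in this assay, with a range from 150000 nM to 1000000 nM.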

Compound 4, half-maximal inhibitory concentration: 3880 nM
Compound 4: the middle estimate sits 120-fold (2.06 log units) above what was measured, and the stated range ends above it.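

In this assay, the change from 4-chlorophenyl to 4-fluorophenyl gives a 45-fold lower number from compound 3 to compound 4 (1.65 log units; beyond the scatter), which shows that the choice of halogen at this position matters a great deal, something the step from hydrogen to chloro could not reveal. Fluoro in place of hydrogen at the same position gives an at least 250-fold lower number from compound 1 to compound 4 (2.41 log units; beyond the scatter), so with the cyclopentyl group held constant, fluoro also makes a large difference against the unsubstituted ring. Fluoro does not do this alone, as cyclopentyl in place of hydrogen on the oxygen gives an at least 250-fold lower number from compound 2 to compound 4 (2.41 log units; beyond the scatter), and both of these last two steps start from a value that is a limit and not a number: the limit of > 1000000 nM in this assay, at which 2 of the 4 values shown sit.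

The compounds shown leave open how other groups at this position would compare, such as bromo, methoxy or an amine, and whether the large gain from chloro to fluoro would hold with something other than cyclopentyl on the oxygen, such as a methyl group or a longer chain. They also cannot tell why fluoro and chloro differ so widely here.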